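The source may hold more compounds than are shown below. What is called first, only, known or untested is meant among the compounds shown, and "the series" means these compounds.

Measured so far in an assay on HEK293 cells for inhibition of Fatty-acid amide hydrolase 1 (Homo sapiens), read by fluorescence; a higher number here means a weaker inhibitor, a lower number a stronger inhibitor:
Compound 1 `N#Cc1cc(-c2ccc3oc(NC4CCCCC4)nc3c2)ccc1O` gives 54 nM.
Compound 2 `Cn1ccc2cc(-c3ccc4oc(NC5CCCCC5)nc4c3)ccc21` gives 911 nM.

Of these two numbers, compound 2 carries the higher one, which in this assay means it is the weaker inhibitor of the pair; the gap to compound 1 is beyond the usual scatter of repeated measurements. For the measured compounds named here, no two measured compounds differ from each other in only one place, so there is no measured single step to lean on.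

Compound 3 `c1cc2c(ccn2C2COC2)cc1-c1ccc2oc(NC3CCCCC3)nc2c1` is drawn from compound 2 by one change: oxetan-3-yl in place of methyl on an aromatic nitrogen. Going by the values given here, nothing among the measured compounds shows what this kind of change does in this assay. With no number pointing one way or the other, the expectation for this assay is a step of no clear direction and of a size that stays within the scatter, while the range around that expectation is kept wide to allow for a shift either way.

Compound 3 is therefore estimated at about 900 nM, between 300 nM and 2700 nM, which corresponds to an expected step of a 1.0-fold lower number from compound 2 to compound 3 (0.01 log units; within the scatter).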

Compound 3, half-maximal inhibitory concentration: 579 nM
Beside the measured number, compound 3's estimate is 1.6-fold (0.19 log units) above it; low and high end bracket the measured number.
By their numbers in this assay, from the lowest: compound 1; then compounds 3 and 2 (each within the scatter of the next).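

In this assay, for the compounds shown here, putting oxetan-3-yl in place of methyl on the aromatic nitrogen gives a 1.6-fold lower number from compound 2 to compound 3 (0.20 log units; within the scatter), the first measured step in this set between compounds that differ in only one place. It shows that this nitrogen can carry a group of four heavy atoms, with a four-membered non-aromatic ring and a hydrogen-bond acceptor, instead of a single carbon, and the result still cannot be told apart from the ordinary spread of repeated measurements. No supporting measurement is available to explain this outcome.

This single swap leaves open how far the position stays this forgiving: a longer chain such as n-butyl, a ring carrying a basic amine such as piperidin-4-yl, or a chain ending in a carboxylic acid could each behave quite differently on the same nitrogen. Going by these compounds alone, it also leaves open whether the same swap would give a similar step on a compound with a different group elsewhere, since only this one pair of compounds speaks to it.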